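Swapping the aryl on the ring nitrogen of compound 1

The compounds below may be only part of what the source reports. "The series", "measured", "known", "first", "only" and "open" are said of these compounds alone.

Compound 1 `CC1=NN(c2cccc(Cl)c2)C(=O)C12C=CC(=O)C=C2c1cccc(C)c1` is the weakest-performing member of a small set of three in a functional assay on A549 cells (Homo sapiens) for antiproliferative activity, read by CCK-8 assay, with a stated time of 72 h (on this read-out higher numbers stand for weaker inhibition and lower numbers for stronger inhibition), where compound 1 gives 20100 nM. Its closest neighbour is compound 2 `CC1=NN(c2cccc(Cl)c2)C(=O)C12C=CC(=O)C=C2c1ccccc1`, which in this assay gives 18800 nM; the step of a 1.1-fold lower number from compound 1 to compound 2 (0.03 log units; within the scatter) is too small to read as a real difference. Compound 3 `CC1=NN(c2cccc(Cl)c2)C(=O)C12C=CC(=O)C=C2c1ccc(C)cc1` stands furthest away, giving 9050 nM in this assay, so that the step of a 2.2-fold lower number from compound 1 to compound 3 (0.35 log units; beyond the scatter) and likewise a 2.1-fold lower number from compound 2 to compound 3 (0.32 log units; beyond the scatter) both count as modest but genuine gains.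

Compound 4 `CC1=NN(c2ccc(Br)cc2)C(=O)C12C=CC(=O)C=C2c1cccc(C)c1` differs from compound 1 in another part of the molecule entirely: 4-bromophenyl in place of 3-chlorophenyl on an amide-type nitrogen in a ring. All three measured steps concern the methyl on the aryl attached to the double-bonded ring carbon, and none alters the aryl on the amide-type nitrogen in a ring. Going by the values given here, there is therefore no measured step that bears on this change, and no movement beyond the scatter is expected. In this assay compound 4 is estimated at 20000 nM, within 8000 nM to 50000 nM, which corresponds to an expected step of a 1.0-fold lower number from compound 1 to compound 4 (0.00 log units; within the scatter).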

Compound 4, half-maximal inhibitory concentration: 45400 nM
Compound 4: middle estimate off by 2.3-fold (0.36 log units), on the low side; the range from low to high includes it.
By their numbers in this assay, from the lowest: compound 3; then compounds 2 and 1 (each within the scatter of the next); then compound 4.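

The aryl on the amide-type nitrogen is not a silent spot in the molecule: in this assay, the change from 3-chlorophenyl to 4-bromophenyl gives a 2.3-fold higher number from compound 1 to compound 4 (0.35 log units; beyond the scatter), a modest loss of inhibition. Going by these compounds alone, this is the first sign that this part of the molecule can shift the read-out, as the earlier steps all concerned the methyl on the other aryl. The two groups match in heavy-atom count and in having no hydrogen-bond donors or acceptors, and nothing measured here explains the step.

The halogen and its place on the ring changed together, so a 4-chlorophenyl or a 3-bromophenyl group on the same nitrogen would be needed to separate the two. Also open, as far as these compounds go, is how a non-halogen group, such as an aminophenyl or a pyridine ring, would behave there.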